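The source may report more compounds than this note shows. Statements on the series, on what has been measured and on what is new or still open speak of the compounds shown alone.

Three measured compounds share one core. Compound 1 `Cc1csc(N)c1C(=O)c1ccc(Cl)cc1` carries hydrogen on the aromatic carbon next to the ring sulfur, compound 2 `Cc1c(-c2ccccc2)sc(N)c1C(=O)c1ccc(Cl)cc1` carries a phenyl there, and compound 3 `CC(C)(C)Cc1c(-c2cccc(F)c2F)sc(N)c1C(=O)c1ccc(Cl)cc1` carries a 2,3-difluorophenyl there together with a neopentyl group on the neighbouring ring carbon. In an assay on CHO cells for displacement of a labelled ligand from adenosine receptor A1 (Homo sapiens), read by scintillation counting, tested at 10 uM (on this read-out higher numbers stand for more inhibition at the one concentration tested (going by the name of the read-out) and lower numbers for less inhibition), compound 1 gives 1%, compound 2 gives 1% and compound 3 gives 1%. Within the data shown here, the one step between compounds differing in a single place, no change at the digits printed from compound 1 to compound 2 (within the scatter), lies within the scatter, and the values of compound 2 and compound 3 are likewise within the scatter of each other. Compound 3 therefore stands level with compound 1 and compound 2; all three sit at the bottom of this read-out.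

Compound 4 `COc1ccccc1-c1sc(N)c(C(=O)c2ccc(Cl)cc2)c1CC(C)(C)C` differs from compound 3 in one place: 2-methoxyphenyl in place of 2,3-difluorophenyl on an aromatic carbon. Among the measured compounds shown here, no measured step exchanges one substituted phenyl for another, so the only guidance is indirect: attaching a phenyl to this carbon, no change at the digits printed from compound 1 to compound 2 (within the scatter), moved nothing, and compound 3 with its 2,3-difluorophenyl gives 1%. No step beyond the scatter is expected in this assay. Compound 4 is estimated at 2%, within -6% to 12%, an expected step of a number 1 percentage points higher from compound 3 to compound 4 (within the scatter).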

Compound 4, a percentage reported as inhibition, at one concentration (the size of the read-out at that concentration, not a potency): 1%
Beside the measured number, compound 4's estimate is 1 percentage points above it; the measured number falls inside the stated range.
By their numbers in this assay, from the lowest: compounds 1, 2, 3 and 4 (each within the scatter of the next).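

In this assay, among these compounds, the first exchange of one substituted phenyl for another on the aromatic carbon next to the ring sulfur, 2-methoxyphenyl in place of 2,3-difluorophenyl, gives no change at the digits printed from compound 3 to compound 4 (within the scatter). The entering group swaps two fluorine atoms for one oxygen and brings a hydrogen-bond acceptor that the leaving group lacks, with the same count of heavy atoms, and on this read-out that exchange does not separate the two compounds; with all four compounds sitting at the bottom of the read-out, though, such a result cannot show whether this position matters for the receptor or whether any effect is simply too small to appear at the one concentration tested. Nothing available here offers an explanation for this result.

Going by these compounds, what stays open is whether any group on this phenyl ring, such as an amine or a carboxylic acid, would lift the number clear of the bottom of the read-out. On these data alone, it is equally open whether a longer chain or a cyclohexyl ring in place of the neopentyl group would do so, since both compounds of this step carry the neopentyl group.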